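The source may hold more compounds than are shown below. What is called first, only, known or untested is meant among the compounds shown, and "the series" means these compounds.

Measured so far in a functional assay on L929 cells (Mus musculus) for antiproliferative activity, read by MTT assay; a lower number here means a stronger inhibitor, a higher number a weaker inhibitor
compound 1 `C[C@@H]1[C@H]2CC(=O)[C@H](C)[C@H]2C[C@H]1O[Si](c1ccccc1)(c1ccccc1)C(C)(C)C` gives 7400 nM
compound 2 `C=CCC[C@H]1CC(=O)[C@@H]2C=CC(=O)[C@H]12` gives 20000 nM
compound 3 `O=C1C=C[C@H]2C(=O)C=C[C@@H]12` gives 3000 nM

Compound 1 stands in the middle of these three numbers. Compound 3 (3000 nM) has a lower number and compound 2 (20000 nM) a higher one, and both gaps to compound 1 lie beyond the scatter.

The compound still to be measured is compound 4 `C=CC[C@H]1C(=O)C[C@@H]2[C@@H](C)[C@H](O[Si](c3ccccc3)(c3ccccc3)C(C)(C)C)C[C@@H]21` which keeps the core of compound 1. It has vinyl in place of hydrogen on a saturated chain carbon bound to a saturated ring carbon, so that methyl becomes allyl. For the measured compounds named here, no two measured compounds differ in one place only, so the series gives no direct size for this change. Going by the values given here, the only guide is the narrow spread of the measured values, with compound 3 (3000 nM) at one end and compound 2 (20000 nM) at the other, although their structures differ considerably. No step beyond the scatter is therefore expected in this assay and no direction can be favoured. The estimated step (a 1.1-fold lower number from compound 1 to compound 4 (0.02 log units; within the scatter)) is expected to remain small. The estimate for compound 4 is 7000 nM with an expected range of 3000 nM to 16000 nM for the measurement.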

Compound 4, half-maximal inhibitory concentration: 17800 nM
Beside the measured number, compound 4's estimate is 2.5-fold (0.41 log units) below it; the whole stated range lies below it.
By their numbers in this assay, from the lowest: compound 3; then compound 1; then compounds 4 and 2 (each within the scatter of the next).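

In this assay the series now holds its first comparison of two compounds that differ in one place: vinyl in place of hydrogen on a saturated chain carbon bound to a saturated ring carbon, which turns methyl into allyl, gives a 2.4-fold higher number from compound 1 to compound 4 (0.38 log units; beyond the scatter) as a modest step beyond the scatter. This position on the core of compound 1 therefore responds to substitution, and here the allyl group goes with a weaker inhibitor than the methyl group, although that reading rests on this single pair. No measurement at hand explains the step.

From the compounds shown here alone, it remains open whether the step follows the double bond or the added chain length, a distinction that a saturated propyl group at this place could draw, and whether a longer chain would move the number further in the same direction. Going by these compounds, it is equally open whether a chain ending in a hydroxyl group or a primary amine would behave like allyl, and whether the same change would give a step of similar size on a different core.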